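Swapping trifluoromethyl for methyl on the amide carbonyl

The source may report more compounds than this note shows. Statements on the series, on what has been measured and on what is new or still open speak of the compounds shown alone.

Compound 1, `Cc1ccc(N)cc1S(=O)(=O)N(C)/N=C/c1cnn2ccc(C#N)cc12`, gives in an assay on isolated protein for inhibition of phosphatidylinositol 4,5-bisphosphate 3-kinase catalytic subunit beta isoform (Homo sapiens), read by 33P incorporation, with a stated time of 60 min (on this read-out higher numbers stand for weaker inhibition and lower numbers for stronger inhibition), the assay limit > 1000 nM.
Compound 2, `Cc1ccc(Br)cc1S(=O)(=O)N(C)/N=C/c1cnn2ccc(C#N)cc12`, gives in this assay 620 nM.
Compound 3, `Cc1ccc(NC(=O)C(F)(F)F)cc1S(=O)(=O)N(C)/N=C/c1cnn2ccc(C#N)cc12`, gives in this assay the assay limit > 1000 nM.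

Compound 3 therefore stands at the limit of this assay, where no number is read, and it shares that position with compound 1 (the limit of > 1000 nM in this assay, at which 2 of the 3 values shown sit). Only compound 2 yields a number among the three.

Compound 4, `CC(=O)Nc1ccc(C)c(S(=O)(=O)N(C)/N=C/c2cnn3ccc(C#N)cc23)c1`, differs from compound 3 in one place: methyl in place of trifluoromethyl on a carbonyl carbon. The measured steps that lead into compound 3 are a step that the two limits leave unreadable from compound 1 to compound 3 and an at least 1.6-fold higher number from compound 2 to compound 3 (0.20 log units; that floor lies within the scatter). Among the measured compounds shown here, neither of these alters the carbonyl carbon itself, so no measured step speaks directly to the exchange of trifluoromethyl for methyl, and the step from compound 2 gives only a floor. What the data do show is that both compounds with a nitrogen on the ring at this place sit at the limit (the limit of > 1000 nM in this assay, at which 2 of the 3 values shown sit).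

On that basis compound 4 is expected to remain weak, with a step that the limit leaves unreadable from compound 3 to compound 4 that need not reach beyond the scatter. The estimate for compound 4 in this assay is 1500 nM, within a range from 500 nM to 5000 nM.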

Compound 4, half-maximal inhibitory concentration: > 1000 nM
Compound 4 gave a limit, no number; the forecaster's own chance of this, stated with the estimate: 60%; the middle value does not contradict the limit.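

In this assay compound 4 gives a limit, > 1000 nM, and not a number. With methyl in place of trifluoromethyl on the carbonyl carbon, no number appears, and all three compounds shown with a nitrogen on the ring at this place now sit at the limit: the limit of > 1000 nM in this assay, at which 3 of the 4 values shown sit. Acetamido in place of bromo gives an at least 1.6-fold higher number from compound 2 to compound 4 (0.20 log units; that floor lies within the scatter), while the steps among compound 1, compound 3 and compound 4 cannot be read, each having a limit at both ends.

From the compounds shown here alone, how far compound 1, compound 3 and compound 4 lie beyond the limit stays open, so it cannot be told whether trifluoromethyl and methyl on the carbonyl carbon differ at all in this assay. Also open, going by these compounds, is whether another group on the ring at this place, such as a chlorine atom, a methoxy group or a carboxylic acid, or a longer chain on the carbonyl, such as propanoyl, would give a readable number, and how any such number would compare with compound 2, which gives 620 nM.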